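A dichlorophenyl urea in place of a nitrophenyl thiourea

The compounds below may be only part of what the source reports. "The series", "measured", "known", "first", "only" and "open" are said of these compounds alone.

Compound 3 `CC(C)c1ccc(Oc2ccc(O)c(O)c2)c(-c2ccsc2S(=O)(=O)NCCNC(=S)Nc2ccc([N+](=O)[O-])cc2)c1` stands at a limit in a functional assay on HeLa cells (Homo sapiens) for inhibition, read by CCK-8 assay, with a stated time of 48 h; on this read-out lower numbers stand for stronger inhibition and higher numbers for weaker inhibition: it reports > 20000 nM, which is a limit of the assay and not a number. Compound 1 `COc1ccc(Oc2ccccc2-c2ccsc2S(=O)(=O)N2CCN(C(=O)Nc3ccc([N+](=O)[O-])cc3)CC2)cc1OC` likewise gives only a limit in this assay, > 50000 nM. Compound 2 `COc1ccc(Oc2ccc(C(C)C)cc2-c2ccsc2S(=O)(=O)NCCNC(=O)Nc2cc(Cl)cc(Cl)c2)cc1OC`, which carries the same (3,5-dichlorophenyl)carbamoyl group that enters here, gives 11600 nM in this assay. Compound 4 `CC(C)c1ccc(Oc2ccc(O)c(O)c2)c(-c2ccsc2S(=O)(=O)NCCNC(=O)Nc2cc(Cl)cc(Cl)c2)c1` differs from compound 3 in one place: a group of 11 heavy atoms (7 carbon, 1 nitrogen, 1 oxygen, 2 chlorine; one six-membered aromatic ring of carbon only) in place of a group of 12 heavy atoms (7 carbon, 2 nitrogen, 2 oxygen, 1 sulfur; one six-membered aromatic ring of carbon only), on an amine nitrogen. For the measured compounds named here, no step between measured compounds is available, so in this assay the change from compound 3 to compound 4 is expected to bring at most a modest gain, since compound 3 shows only a limit (the limit of > 20000 nM in this assay, at which 1 of the 3 values shown sits). Compound 4 is expected to give 15000 nM in this assay, within 5000 nM to 50000 nM, an estimated step of an at least 1.3-fold lower number from compound 3 to compound 4 (0.12 log units; that floor lies within the scatter).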

Compound 4, half-maximal inhibitory concentration: > 50000 nM
Compound 4 ended at the assay's limit (the forecaster's own chance of this, stated with the estimate: 45%); middle value at least 3.3-fold (0.52 log units) away from the limit.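

The exchange on the amine nitrogen itself gives no size: compound 3 and compound 4 both stand at limits, so that step cannot be read. What the result does show lies on the other side of the molecule: with the (3,5-dichlorophenyl)carbamoyl group held in place, putting 3,4-dihydroxyphenyl in place of 3,4-dimethoxyphenyl on an oxygen on an aromatic ring gives an at least 4.3-fold higher number from compound 2 to compound 4 (0.63 log units; beyond the scatter) in this assay. The compounds shown leave open whether a 3-hydroxy-4-methoxyphenyl group would hold the value of compound 2 or fall to a limit like compound 4.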